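Swapping oxolan-3-yl for methyl on the aromatic oxygen

The source may report more compounds than this note shows. Statements on the series, on what has been measured and on what is new or still open speak of the compounds shown alone.

Measured so far in a functional assay on PC-3 cells (Homo sapiens) for cytotoxicity, read by MTT assay, with a stated time of 72 h (a higher number here means a weaker inhibitor, a lower number a stronger inhibitor), with these results
Compound 1 `COc1ccc(OC)c(/C=C/C(=O)Nc2cc3c(Nc4ccc(F)c(Cl)c4)ncnc3cc2OC)c1` gives 28600 nM
Compound 2 `COc1ccc(/C=C/C(=O)Nc2cc3c(Nc4ccc(F)c(Cl)c4)ncnc3cc2OC)cc1` gives "not active" (no number reported)
Compound 3 `N#Cc1ccc(/C=C/C(=O)Nc2cc3c(Nc4ccc(F)c(Cl)c4)ncnc3cc2O[C@H]2CCOC2)cc1` gives 36600 nM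

Compound 3 lies within the usual scatter of compound 1 in this assay and no order can be drawn between the two. Compound 2 has no number to compare. Compound 4 `COc1cc2ncnc(Nc3ccc(F)c(Cl)c3)c2cc1NC(=O)/C=C/c1ccc(C#N)cc1` differs from compound 3 by a single change methyl in place of oxolan-3-yl on an oxygen on an aromatic ring and so carries methyl in place of oxolan-3-yl on an oxygen on an aromatic ring.

Among the measured compounds shown here, no pair of measured compounds shows this change alone, so its size can only be judged indirectly. The methoxy of compound 4 also occurs in compound 1 at 28600 nM and in compound 2 as "not active" (no number reported) while other groups differ, which points in no clear direction. No step beyond the scatter is expected, and the estimated 1.1-fold lower number from compound 3 to compound 4 (0.04 log units; within the scatter) reflects that view. For compound 4 the estimate is 33000 nM with a range of 13000 nM to 75000 nM expected.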

Compound 4, half-maximal inhibitory concentration: "not active" (no number reported)
The entry for compound 4 holds no number, so the estimate cannot be set against anything.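

In this assay compound 3 gives 36600 nM and compound 4 gives "not active" (no number reported), so no step can be read between compound 3 and compound 4. No measured evidence bears on this result. The compounds shown leave open how far methoxy and (oxolan-3-yl)oxy differ on this read-out.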